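The source may hold more compounds than are shown below. What is called first, only, known or untested is meant among the compounds shown, and "the series" means these compounds.

Measured so far in a functional assay on MCF7 cells (Homo sapiens) for cytotoxicity, read by MTT assay, with a stated time of 96 h; on this read-out lower numbers stand for stronger inhibition and higher numbers for weaker inhibition:
Compound 1 `Cc1cc2c(c(=O)o1)C(c1ccccc1)C(C#N)=C(N)O2` gives 46000 nM.
Compound 2 `Cc1cc2c(c(=O)o1)C(c1c[nH]c3ccccc13)C(C#N)=C(N)O2` gives 10000 nM.
Compound 3 `Cc1cc2c(c(=O)o1)C(c1c[nH]c3ccc(C#N)cc13)C(C#N)=C(N)O2` gives 7000 nM.

Compound 1 stands highest of the three, with compound 2 and compound 3 both lying beyond the scatter below it. Compound 4 `Cc1ccc(C2C(C#N)=C(N)Oc3cc(C)oc(=O)c32)cc1` differs from compound 1 by methyl in place of hydrogen on an aromatic carbon. Among the measured compounds shown here, the only measured step that adds a small group to an aromatic ring is a 1.4-fold lower number from compound 2 to compound 3 (0.15 log units; within the scatter), a change that stayed within the scatter. For the measured compounds named here, a methyl entering the phenyl of compound 1 has no direct precedent among the measured compounds, so nothing here supports expecting a step beyond the scatter in this assay in either direction. Compound 4 is therefore expected to give 40000 nM, with a range from 15000 nM to 100000 nM. This estimate means a 1.2-fold lower number from compound 1 to compound 4 (0.06 log units; within the scatter), which is expected to stay within the scatter.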

Compound 4, half-maximal inhibitory concentration: 54000 nM
The estimate for compound 4 lay 1.4-fold (0.13 log units) below the measured number; measured number inside the range.
By their numbers in this assay, from the lowest: compounds 3 and 2 (each within the scatter of the next); then compounds 1 and 4 (each within the scatter of the next).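

In this assay, going from phenyl to 4-methylphenyl gives a 1.2-fold higher number from compound 1 to compound 4 (0.07 log units; within the scatter), so compound 1 and compound 4 cannot be told apart on this read-out. On this six-membered aromatic ring, then, a methyl para to a large group is tolerated without a step beyond the scatter. No supporting evidence bears on why this is so.

Going by these compounds, whether an amine or a carboxylic acid at this same place would also stay within the scatter remains open. So does the effect of a longer chain, such as propyl.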